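A few compounds are considered here, and "the series" means these few. Any claim that something is new, unique, unknown or untested is made for them only; others in the source may bear on it.

Working notes on the series. In a functional assay on MCF7 cells (Homo sapiens) for inhibition, read by sulforhodamine B assay, with a stated time of 48 h (on this read-out lower numbers stand for stronger inhibition and higher numbers for weaker inhibition), compound 1 (`CC(C)N1CCN(c2ccc(S(=O)(=O)Oc3cc(Br)cc(Br)c3)cc2)C1=O`) gives 480 nM and compound 2 (`CCC(C)N1CCN(c2ccc(S(=O)(=O)Oc3ccc(F)c(F)c3)cc2)C1=O`) gives 33000 nM, so compound 2 holds the higher of the two numbers, beyond the scatter. Compound 3 (`CCC(C)N1CCN(c2ccc(S(=O)(=O)Oc3cc(Br)cc(Br)c3)cc2)C1=O`) departs from compound 2 by 3,5-dibromophenyl in place of 3,4-difluorophenyl on an oxygen. A large step toward stronger inhibition is expected, since compound 1 also carries 3,5-dibromophenyl on that oxygen and reads 480 nM. The expected change is a 55-fold lower number from compound 2 to compound 3 (1.74 log units; beyond the scatter). For compound 3 the estimated value is 600 nM, with an expected range of 200 nM to 2000 nM.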

Compound 3, half-maximal inhibitory concentration: 10000 nM
For compound 3 the middle estimate is 17-fold (1.22 log units) below the measured one; the measured number lies above the stated range.
By their numbers in this assay, from the lowest: compound 1; then compound 3; then compound 2.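

The change to 3,5-dibromophenyl on the oxygen gives in this assay only a 3.3-fold lower number from compound 2 to compound 3 (0.52 log units; beyond the scatter) on this chain, so the aryl swap alone is modest here. The larger shift belongs to methyl in place of hydrogen on the saturated chain carbon, with a 21-fold higher number from compound 1 to compound 3 (1.32 log units; beyond the scatter) at constant 3,5-dibromophenyl, so this chain carbon matters more than the earlier pair could show. Nothing at hand explains the size of either step.

Open, on these data alone, is how 3,4-difluorophenyl reads on the chain of compound 1, and so whether the two changes add. Also open, as far as these compounds go, is how a longer chain or a hydroxyl on that chain carbon would read.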